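This account rests on a few compounds, and the source may have more. Where it says the series, first, only, none or still open, it means among the compounds named here.

Compound 3 `COc1ccc(Cn2cc(/C=N\NC(=O)c3cn(C)c4ccccc34)c3ccc(F)cc32)cc1` stands as the weakest of the three measured compounds: in a functional assay on MIA PaCa-2 cells (Homo sapiens) for cytotoxicity (on this read-out lower numbers stand for stronger inhibition and higher numbers for weaker inhibition), compound 3 gives 55800 nM. Compound 1 `COc1ccc2c(c1)c(/C=N\NC(=O)c1c[nH]c3ccc(Br)cc13)cn2Cc1ccc(Cl)cc1` gives 26300 nM in this assay, and compound 2 `O=C(N/N=C\c1cn(Cc2ccc(Cl)cc2)c2ccc(Br)cc12)c1c[nH]c2ccccc12` gives 8700 nM; both gaps to compound 3 lie beyond the scatter. Compound 4 `COc1ccc(Cn2cc(/C=N\NC(=O)c3c[nH]c4ccc(Br)cc34)c3ccc(F)cc32)cc1` has not been measured. It differs from compound 3 in one place: 5-bromo-1H-indol-3-yl in place of 1-methyl-1H-indol-3-yl on a carbonyl carbon. Within the data shown here, no measured pair shows this change on its own, so its size is open. Compound 1 also carries the 5-bromo-1H-indol-3-yl group and gives 26300 nM, a lower number than compound 3. On that basis a modest step towards a lower number is expected, of the size a 2.2-fold lower number from compound 3 to compound 4 (0.35 log units; beyond the scatter). For compound 4 the estimated value is 25000 nM, between 8000 nM and 70000 nM.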

Compound 4, half-maximal inhibitory concentration: 45500 nM
Estimate against measurement, compound 4: 1.8-fold (0.26 log units) below; the measured number falls inside the stated range.
By their numbers in this assay, from the lowest: compound 2; then compounds 1, 4 and 3 (each within the scatter of the next, the first and the last beyond it).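

In this assay, placing 5-bromo-1H-indol-3-yl on the carbonyl carbon in place of 1-methyl-1H-indol-3-yl gives a 1.2-fold lower number from compound 3 to compound 4 (0.09 log units; within the scatter). On this core the two groups therefore cannot be told apart, so this position tolerates the exchange of the amide-side indoles without a readable shift. Nothing available explains this result.

Still open, as far as these compounds go, is whether the bromine and the loss of the methyl would each shift the number when taken singly. Also open, from the compounds shown here alone, is whether a different group on the carbonyl carbon, such as a pyridine ring or a carboxylic acid, would separate from these indoles.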